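Methyl to Bromo: a Small Change, a Small Step

The source may hold more compounds than are shown below. What is called first, only, known or untested is meant among the compounds shown, and "the series" means these compounds.

Compound 1: `COC(=O)[C@@]1(C)CCC=C2[C@@H]1CC[C@@H](C)[C@]2(C)Cc1c[nH]c2c(C)cccc12` gives 26000 nM
Compound 2: `COC(=O)[C@@]1(C)CCC=C2[C@@H]1CC[C@@H](C)[C@]2(C)Cc1c[nH]c2c(Br)cccc12` gives 32000 nM
Compound 3: `COC(=O)[C@@]1(C)CCC=C2[C@@H]1CC[C@@H](C)[C@]2(C)Cc1c(C)[nH]c2ccc(C)cc12` gives 28000 nM

Of the compounds shown here, three have been measured in a functional assay on WiDr cells (Homo sapiens) for inhibition, read by sulforhodamine B assay, with a stated time of 48 h; a lower number here means a stronger inhibitor of growth, a higher number a weaker inhibitor of growth. All three numbers lie within the scatter of each other, so none can be called a weaker or stronger inhibitor of growth than another. Compound 1 and compound 2 share a core and differ in one place: bromo in place of methyl on an aromatic carbon. This exchange gave a 1.2-fold higher number from compound 1 to compound 2 (0.09 log units; within the scatter). Compound 3 carries a different core; how the core of compound 3 differs from the core of compound 1 is not broken down here.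

Compound 4 is `COC(=O)[C@@]1(C)CCC=C2[C@@H]1CC[C@@H](C)[C@]2(C)Cc1c(C)[nH]c2ccc(Br)cc12`, not yet measured. It differs from compound 3 in one place: bromo in place of methyl on an aromatic carbon. Among the compounds with values here, this is the same kind of change as the one from compound 1 to compound 2, but not the same change: in the earlier pair the bromo is ortho to a fused ring and meta to a fused ring, whereas in compound 4 it is meta to a fused ring and para to a fused ring. Because a 1.2-fold higher number from compound 1 to compound 2 (0.09 log units; within the scatter) was the outcome of the earlier exchange, a similarly small step is expected here: a 1.2-fold higher number from compound 3 to compound 4 (0.07 log units; within the scatter). Compound 4 is therefore estimated at 33000 nM in this assay, with a likely range from 16000 nM to 66000 nM.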

Compound 4, concentration for 50% growth inhibition: 15000 nM
The estimate for compound 4 lay 2.2-fold (0.34 log units) above the measured number, outside the stated range (below it).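

In this assay, the exchange of methyl for bromo on an aromatic carbon gave a 1.9-fold lower number from compound 3 to compound 4 (0.27 log units; within the scatter), so on this core, as on the earlier one, the step cannot be told apart from the ordinary spread of repeated measurements. Although the two steps appear to point in opposite directions, the gap between them is no real disagreement: the same change on two cores in this assay, a 1.2-fold higher number (0.09 log units; within the scatter) from compound 1 to compound 2 and a 1.9-fold lower number (0.27 log units; within the scatter) from compound 3 to compound 4, 2.3-fold (0.36 log units) apart, within the scatter of two such steps. Within the data shown here, this shows that across these two cores the change has left no mark that stands clear of the scatter, but it does not show that the change has no effect in general or that the two cores respond alike; the bromo sits at a different place in each pair, and each core offers only one pair.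

The compounds shown carry only methyl or bromo at these aromatic carbons, so it remains open what an amine, a carboxylic acid or a longer chain would do there. From the compounds shown here alone, it also remains open whether any of these groups would move the number beyond the scatter on either core.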